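Pyrazolyl Amide in Place of Methoxymethyl on a Macrolide

The source may hold more compounds than are shown below. What is called first, only, known or untested is meant among the compounds shown, and "the series" means these compounds.

Compound 1 `CCCCCCCC(=O)NCCCN(C)[C@H]1C[C@@H](C)O[C@@H](O[C@@H]2[C@@H](C)[C@H](O[C@H]3C[C@@](C)(OC)[C@@H](O)[C@H](C)O3)[C@@H](C)C(=O)O[C@H](CC)[C@@](C)(O)[C@H](O)[C@@H](C)C(=O)[C@H](C)C[C@@]2(C)OC)[C@@H]1O`, compound 2 `CC[C@H]1OC(=O)[C@H](C)[C@@H](O[C@H]2C[C@@](C)(OC)[C@@H](O)[C@H](C)O2)[C@H](C)[C@@H](O[C@@H]2O[C@H](C)C[C@H](N(C)C)[C@H]2O)[C@](C)(O)C[C@@H](C)CN(C)[C@H](C)[C@@H](OCCCNC(=O)COC)[C@]1(C)O` and compound 3 `CC[C@H]1OC(=O)[C@H](C)[C@@H](O[C@H]2C[C@@](C)(OC)[C@@H](O)[C@H](C)O2)[C@H](C)[C@@H](O[C@@H]2O[C@H](C)C[C@H](N(C)C)[C@H]2O)[C@](C)(O)C[C@@H](C)CN(CCCNC(=O)c2c(C)nn(C)c2Cl)[C@H](C)[C@@H](O)[C@]1(C)O` have been measured in a physicochemical assay for lipophilicity, read by HPLC, measured as chromatographic lipophilicity, at pH 7.4; a higher number here means a more lipophilic compound, a lower number a more polar compound. Compound 1 gives 6.44, compound 2 gives 2.58 and compound 3 gives 2.2. Among these three numbers compound 2 stands second highest: compound 3 sits below it by a gap beyond the usual scatter, and compound 1 stands far above it, also beyond the scatter. Compound 4 `CC[C@H]1OC(=O)[C@H](C)[C@@H](O[C@H]2C[C@@](C)(OC)[C@@H](O)[C@H](C)O2)[C@H](C)[C@@H](O[C@@H]2O[C@H](C)C[C@H](N(C)C)[C@H]2O)[C@](C)(O)C[C@@H](C)CN(C)[C@H](C)[C@@H](OCCCNC(=O)c2c(C)nn(C)c2Cl)[C@]1(C)O` has not been measured. It differs from compound 2 in one place: 5-chloro-1,3-dimethyl-1H-pyrazol-4-yl in place of methoxymethyl on a carbonyl carbon. Among the measured compounds shown here, no measured pair shows exactly this step; the expectation rests on what enters, an aromatic ring carrying chlorine replacing a short chain. The estimated step, a number 0.72 log units higher from compound 2 to compound 4 (beyond the scatter), is an increase beyond the scatter. Compound 4 is expected to give 3.3, within 2.7 to 3.9.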

Compound 4, distribution coefficient: 3.01
For compound 4 the middle estimate is 0.29 log units above the measured one, within the range that was stated.
By their numbers in this assay, from the lowest: compound 3; then compound 2; then compound 4; then compound 1.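

In this assay the exchange of methoxymethyl for 5-chloro-1,3-dimethyl-1H-pyrazol-4-yl on this carbonyl carbon gives a number 0.43 log units higher from compound 2 to compound 4 (beyond the scatter), a modest step. Among the compounds shown here, the earlier compounds held no pair differing in one place, so this is the first reading of a single change here. Nothing available explains the size of this step. Still open, from the compounds shown here alone, is whether the chlorine or the methyl groups on the ring carry the step, and how a phenyl ring, a longer chain or an amine on the same carbonyl carbon would read.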